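A tetrazole gives way to an oxazole

The source may hold more compounds than are shown below. What is called first, only, known or untested is meant among the compounds shown, and "the series" means these compounds.

Compound 3 `CCCCOC(=O)NS(=O)(=O)c1sc(CC(C)C)cc1-c1ccc(Cn2ncnn2)cc1` gives 16 nM in an assay on membranes from uterus for displacement of a labelled ligand from Angiotensin type II receptor (Sus scrofa), with a stated time of 1.5 h (a higher number here means a weaker inhibitor, a lower number a stronger inhibitor), the lowest of the two numbers shown; compound 2 `CCCCOC(=O)NS(=O)(=O)c1sc(CC(C)C)cc1-c1ccc(CN2CCN(C)C2=O)cc1` stands at 16.5 nM, and a 1.0-fold lower number from compound 2 to compound 3 (0.01 log units; within the scatter). Compound 1 `CCCCOC(=O)NS(=O)(=O)c1sc(CC(C)C)cc1-c1ccc(CN2C(=O)CCC2=O)cc1` reaches only a limit of this assay, > 10000 nM, as noted in the limit of > 10000 nM in this assay, at which 1 of the 3 values shown sits. Compound 4 `CCCCOC(=O)NS(=O)(=O)c1sc(CC(C)C)cc1-c1ccc(Cc2ncco2)cc1` differs from compound 3 by 1,3-oxazol-2-yl in place of 2H-tetrazol-2-yl on a saturated chain carbon bound to an aromatic carbon. For the measured compounds named here, two measured steps touch this position: an at least 620-fold lower number from compound 1 to compound 3 (2.79 log units; beyond the scatter), and a 1.0-fold lower number from compound 2 to compound 3 (0.01 log units; within the scatter). The second shows that exchanging one neutral group for another at this place left the number unchanged, so a small step in this assay is expected, if any. Compound 4 is therefore estimated at 30 nM (range 8 nM to 120 nM), which would mean a 1.9-fold higher number from compound 3 to compound 4 (0.27 log units; within the scatter).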

Compound 4, inhibition constant: 3.9 nM
For compound 4 the middle estimate is 7.7-fold (0.89 log units) above the measured one, and the stated range ends above it.
By their numbers in this assay, from the lowest: compound 4; then compounds 3 and 2 (each within the scatter of the next). At a limit, above all of these: compound 1.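

In this assay the 1,3-oxazol-2-yl group parts from the two groups that had stood level, with a 4.1-fold lower number from compound 3 to compound 4 (0.61 log units; beyond the scatter) and with a 4.2-fold lower number from compound 2 to compound 4 (0.63 log units; beyond the scatter). Both 2H-tetrazol-2-yl and 1,3-oxazol-2-yl are five-membered aromatic rings, so ring size alone does not set the number at this place. The widest step, an at least 2500-fold lower number from compound 1 to compound 4 (3.40 log units; beyond the scatter), is only a bound, since compound 1 stands at a limit: the limit of > 10000 nM in this assay, at which 1 of the 4 values shown sits.

From the compounds shown here alone, it remains open whether an amine or a carboxylic acid carried on this saturated chain carbon would keep such a number.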